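From Fluoro to Amino: One More Swap

The source may hold more compounds than are shown below. What is called first, only, known or untested is meant among the compounds shown, and "the series" means these compounds.

In a functional assay on MGC-803 cells (Homo sapiens) for inhibition, read by MTT assay, with a stated time of 48 h (a lower number here means a stronger inhibitor, a higher number a weaker inhibitor), compound 1 `COc1ccc(CNc2cc(OC)c(OC)c(OC)c2)cc1[N+](=O)[O-]` gives 19400 nM and compound 2 `COc1ccc(CNc2cc(OC)c(OC)c(OC)c2)cc1F` gives 39700 nM. Compound 2 therefore has the higher number of the pair, which makes it the weaker inhibitor of the two.

The next structure, compound 3 `COc1ccc(CNc2cc(OC)c(OC)c(OC)c2)cc1N`, keeps the rest of compound 2 and changes one group: amino in place of fluoro on an aromatic carbon. Amino thus takes the place of fluoro on an aromatic carbon.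

Within the data shown here, only one measured step bears on this change, since it involves the same carbon: a 2.0-fold higher number from compound 1 to compound 2 (0.31 log units; beyond the scatter). That step, fluoro in place of nitro, is modest but beyond the scatter. Among the measured compounds shown here, one step cannot set a direction firmly, and no measured compound here carries amino. For the measured compounds named here, the only other group measured at this carbon, in compound 1, gave the lower number, so a modest move towards stronger inhibition in this assay is expected, with a wide margin.

The expected change is a 2.2-fold lower number from compound 2 to compound 3 (0.34 log units; beyond the scatter). For compound 3 the estimated value is 18000 nM, with an expected range from 4000 nM to 50000 nM.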

Compound 3, half-maximal inhibitory concentration: 7970 nM
Compound 3: the middle estimate sits 2.3-fold (0.35 log units) above what was measured; measured number inside the range.
By their numbers in this assay, from the lowest: compound 3; then compound 1; then compound 2.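

At this carbon, amino gives a 5.0-fold lower number from compound 2 to compound 3 (0.70 log units; beyond the scatter) in this assay and also a 2.4-fold lower number from compound 1 to compound 3 (0.39 log units; beyond the scatter), so the number at this one position can fall below the values of both earlier groups, and amino makes compound 3 the strongest inhibitor of the three. Among these compounds, the earlier pair showed only that fluoro stands above nitro, whereas the order now runs from amino through nitro to fluoro, and the swap from fluoro to amino is a larger step than a 2.0-fold higher number from compound 1 to compound 2 (0.31 log units; beyond the scatter), the one step known before. The swap also brings one hydrogen-bond donor and one hydrogen-bond acceptor where fluoro has none, but that is only a count, and nothing available here explains the order of the three groups.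

These three compounds leave open whether the lower number depends on the free amino group itself, or whether a methylamino group or an acetamide at this carbon would also keep it. They also leave open whether a hydroxyl group, which like amino is a small group, would fall near amino, or nearer to nitro or fluoro.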